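This account rests on a few compounds, and the source may have more. Where it says the series, first, only, none or still open, it means among the compounds named here.

Of the compounds shown here, three built on one shared core have been tested in a functional assay on SK-BR-3 cells (Homo sapiens) for antiproliferative activity, read by MTT assay, with a stated time of 72 h; on this read-out higher numbers stand for weaker inhibition and lower numbers for stronger inhibition. Compound 1 `C/C=C1/[C@H](O[C@@H]2O[C@H](COC(C)=O)[C@@H](OC(C)=O)[C@H](OC(C)=O)[C@H]2OC(C)=O)OC=C(C(=O)O)[C@H]1CC(=O)OC` reached only a limit, > 20000 nM, in this assay. Compound 2 `C/C=C1/[C@H](O[C@@H]2O[C@H](CO)[C@@H](O)[C@H](O)[C@H]2O)OC=C(C(=O)OC)[C@H]1CC(=O)OC` likewise gave a limit, > 15000 nM, in this assay. Compound 3 `C/C=C1/[C@H](O[C@@H]2O[C@H](COC(C)=O)[C@@H](OC(C)=O)[C@H](OC(C)=O)[C@H]2OC(C)=O)OC=C(C(=O)OC)[C@H]1CC(=O)OCC` also stopped at a limit, > 15000 nM, in this assay. Among the compounds with values here, compound 2 thus stands with the others at the limits of this assay, where the limit of > 15000 nM in this assay, at which 2 of the 3 values shown sit, holds two of the three values and the limit of > 20000 nM in this assay, at which 1 of the 3 values shown sits, the third; no real number separates any of them, and no step between measured compounds can be worked out.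

Compound 4 `C/C=C1/[C@H](O[C@@H]2O[C@H](CO)[C@@H](O)[C@H](O)[C@H]2O)OC=C(C(=O)OC)[C@H]1CC(=O)OCCc1ccc(OC)cc1` has not yet been measured. It differs from compound 2 by one change, (4-methoxybenzyl in place of hydrogen on a saturated chain carbon bound to an oxygen next to a carbonyl group). With every measured value a limit, no step size can be read from the data, so the expected step that the limit leaves unreadable from compound 2 to compound 4 is taken to lie within the usual scatter, or not beyond it in any clear direction. Compound 4 is therefore expected to give about 20000 nM in this assay, with a likely range from 5000 nM to 60000 nM.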

Compound 4, half-maximal inhibitory concentration: > 20000 nM
Compound 4 was reported as a limit (the forecaster's own chance of this, stated with the estimate: 70%); the middle value sits exactly at the limit.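

In this assay compound 4 gives > 20000 nM, which is a limit and not a number. Within the data shown here, compound 2 also stopped at a limit, so no step between the two can be read. The compounds shown leave open whether any of them gives a real number in this assay.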